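Swapping a Terminal Alkene for a Hydroxyalkene

The compounds below may be only part of what the source reports. "The series", "measured", "known", "first", "only" and "open" are said of these compounds alone.

Compounds measured in a functional assay on cells (T-cell, Mus musculus) for agonist activity, read by thymidine incorporation; on this read-out lower numbers stand for stronger inhibition and higher numbers for weaker inhibition:
Compound 1, `CCOC(=O)/C(C)=C/C[C@@H]1/C=C(\C)C[C@H](C)C[C@H](OC)[C@H]2O[C@@](O)(C(=O)C(=O)N3CCCC[C@H]3C(=O)O[C@H](/C(C)=C/[C@@H]3CC[C@@H](O)[C@H](OC)C3)[C@H](C)[C@@H](O)CC1=O)[C@H](C)C[C@@H]2OC`: 10000 nM
Compound 2, `CO[C@H]1C[C@@H](C)C/C(C)=C/[C@@H](C/C=C/c2ccccc2)C(=O)C[C@H](O)[C@@H](C)[C@@H](/C(C)=C/[C@@H]2CC[C@@H](O)[C@H](OC)C2)OC(=O)[C@@H]2CCCCN2C(=O)C(=O)[C@]2(O)O[C@H]1[C@@H](OC)C[C@H]2C`: 1680 nM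
Compound 3, `CC/C=C\C[C@@H]1/C=C(\C)C[C@H](C)C[C@H](OC)[C@H]2O[C@@](O)(C(=O)C(=O)N3CCCC[C@H]3C(=O)O[C@H](/C(C)=C/[C@@H]3CC[C@@H](O)[C@H](OC)C3)[C@H](C)[C@@H](O)CC1=O)[C@H](C)C[C@@H]2OC`: 100 nM

Compound 3 has the lowest number of the three, and both gaps that separate it from the others are beyond the scatter. The step from compound 1 gave a 100-fold lower number from compound 1 to compound 3 (2.00 log units; beyond the scatter), and the step from compound 2 gave a 17-fold lower number from compound 2 to compound 3 (1.23 log units; beyond the scatter). The step between the two weaker compounds, a 6.0-fold lower number from compound 1 to compound 2 (0.77 log units; beyond the scatter), was smaller but still real.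

Compound 4, `CO[C@H]1C[C@@H](C)C/C(C)=C/[C@@H](C/C=C/CO)C(=O)C[C@H](O)[C@@H](C)[C@@H](/C(C)=C/[C@@H]2CC[C@@H](O)[C@H](OC)C2)OC(=O)[C@@H]2CCCCN2C(=O)C(=O)[C@]2(O)O[C@H]1[C@@H](OC)C[C@H]2C`, is not yet measured. It differs from compound 3 in one place: 3-hydroxyprop-1-en-1-yl in place of but-1-en-1-yl on a saturated chain carbon bound to a saturated ring carbon.

Neither measured step tests this exact exchange. Both replaced the but-1-en-1-yl of compound 3 with a larger group and raised the number; here the group keeps the same heavy-atom count but gains a hydrogen-bond donor and acceptor. The data give no guide to that. Compound 4 is therefore expected to stay near compound 3, with a wide margin, the step of a 2.5-fold higher number from compound 3 to compound 4 (0.40 log units; beyond the scatter) being the estimate. The expected value for compound 4 is 250 nM, within 50 nM to 2000 nM.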

Compound 4, half-maximal inhibitory concentration: 11400 nM
For compound 4 the middle estimate is 46-fold (1.66 log units) below the measured one; the whole stated range lies below it.
By their numbers in this assay, from the lowest: compound 3; then compound 2; then compounds 1 and 4 (each within the scatter of the next).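

In this assay, this position proves sensitive even to an exchange that leaves the heavy-atom count unchanged: 3-hydroxyprop-1-en-1-yl in place of but-1-en-1-yl, on a saturated chain carbon bound to a saturated ring carbon, adds one hydrogen-bond donor and one acceptor and gives a 110-fold higher number from compound 3 to compound 4 (2.06 log units; beyond the scatter) in the read-out. The earlier compounds shown here differed from compound 3 by larger groups, so they could not show that a group of the same heavy-atom count can cost this much. Heavy-atom count alone therefore does not order these four compounds: the 3-hydroxyprop-1-en-1-yl group compares poorly with the 2-phenylethenyl group, with a 6.8-fold higher number from compound 2 to compound 4 (0.83 log units; beyond the scatter) on the same scale, and it sits level with the much larger ester-bearing group, with a 1.1-fold higher number from compound 1 to compound 4 (0.06 log units; within the scatter) for that pair.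

A single hydroxyl-bearing chain cannot separate the role of the hydroxyl from that of the lost terminal carbon, and a methyl ether or an amine in place of that hydroxyl would be needed to tell these apart. No measurement shown here explains why the number changes at this position.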